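Swapping the Oxadiazole for a Dimethylthiazole

The source may report more compounds than this note shows. Statements on the series, on what has been measured and on what is new or still open speak of the compounds shown alone.

Of the compounds shown here, two built on a shared core have been measured in an assay on isolated protein for inhibition of 2-Hydroxyacid oxidase 1 (Homo sapiens), with stated times of 30 min and 15 min; on this read-out lower numbers stand for stronger inhibition and higher numbers for weaker inhibition. Compound 1 `CC(C)c1coc(-c2cccc(CNc3ccc4[nH]nc(C(=O)O)c4c3)c2O)n1` gives 87 nM in this assay. Compound 2 `CC(C)c1noc(-c2cccc(CNc3ccc4[nH]nc(C(=O)O)c4c3)c2O)n1` gives 47 nM, the lower of the two numbers, though the step of a 1.9-fold lower number from compound 1 to compound 2 (0.27 log units; within the scatter) lies within the scatter, so the two compounds cannot be separated on this evidence. Compound 3 `Cc1nc(-c2cccc(CNc3ccc4[nH]nc(C(=O)O)c4c3)c2O)sc1C` has not yet been measured. It differs from compound 2 by 4,5-dimethyl-1,3-thiazol-2-yl in place of 3-isopropyl-1,2,4-oxadiazol-5-yl on an aromatic carbon. Within the data shown here, the only measured step that bears on this change is a 1.9-fold lower number from compound 1 to compound 2 (0.27 log units; within the scatter), which likewise exchanges one five-membered aromatic ring for another on the same aromatic carbon and stays within the scatter. On that single precedent one expects no step beyond the scatter in this assay, with the direction left open, since nothing measured speaks to a thiazole or to its two methyl groups. Compound 3 is therefore estimated at 60 nM, with a range from 20 nM to 180 nM. The expected step of a 1.3-fold higher number from compound 2 to compound 3 (0.11 log units; within the scatter) is accordingly small.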

Compound 3, half-maximal inhibitory concentration in the 2-Hydroxyacid oxidase 1 assay: 25 nM
Estimate against measurement, compound 3: 2.4-fold (0.38 log units) above, within the range that was stated.
By their numbers in the 2-Hydroxyacid oxidase 1 assay, from the lowest: compounds 3, 2 and 1 (each within the scatter of the next, the first and the last beyond it).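

In the 2-Hydroxyacid oxidase 1 assay, the exchange to 4,5-dimethyl-1,3-thiazol-2-yl gives a 1.9-fold lower number from compound 2 to compound 3 (0.27 log units; within the scatter), and against the oxazole it gives a 3.5-fold lower number from compound 1 to compound 3 (0.54 log units; beyond the scatter). Among these compounds, this is the first step at this position, on an aromatic carbon ortho to a hydroxy group, to lie beyond the scatter, although compound 3 still cannot be separated from compound 2. The exchange from the 3-isopropyl-1,2,4-oxadiazol-5-yl group to the thiazole also reaches a physicochemical assay for solubility, measured as kinetic solubility, at pH 7.4 (on this read-out lower numbers stand for lower solubility and higher numbers for higher solubility), where compound 2 gives 227000 nM and compound 3 gives 15000 nM, a step that is large and beyond the scatter: the measured solubility of compound 2, 227000 nM, and of compound 3, 15000 nM, a 15-fold lower number (1.18 log units; beyond the scatter)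

The compounds shown leave open whether the thiazole ring or its two methyl groups carry these steps, as ring and substituents change together between compound 2 and compound 3. A 4-isopropyl-1,3-thiazol-2-yl group, or a thiazole bearing an amine or a carboxylic acid in place of one methyl, could show whether the numbers in the 2-Hydroxyacid oxidase 1 assay can be kept while solubility in the physicochemical assay comes back towards that of compound 2.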